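This account rests on a few compounds, and the source may have more. Where it says the series, first, only, none or still open, it means among the compounds named here.

Going by the values given here, in a functional assay on HTB-54 cells (Homo sapiens) for cytotoxicity, read by MTT assay, with a stated time of 72 h (a lower number here means a stronger inhibitor of growth, a higher number a weaker inhibitor of growth), compound 2 `CC(C)COC(=O)Nc1ccc([Se]C#N)cc1` gives 27100 nM, the higher of the two numbers measured so far. Its nearest neighbour is compound 1 `CCCCOC(=O)Nc1ccc([Se]C#N)cc1`, which in this assay gives 17200 nM; the step of a 1.6-fold higher number from compound 1 to compound 2 (0.20 log units; within the scatter) lies within the scatter, so the two compounds cannot be ordered on this evidence. Compound 3 `CCCCCCOC(=O)Nc1ccc([Se]C#N)cc1` differs from compound 2 by pentyl in place of isopropyl on a saturated chain carbon bound to an oxygen next to a carbonyl group. Among the compounds with values here, only the single step from compound 1 to compound 2 bears on this change, and it concerns a branched against a straight chain of the same size, not a longer chain; it gives no sign of a shift beyond the scatter. A lengthening of the chain has not been tested among these compounds, so no direction can be read from the data. Compound 3 is therefore expected to sit close to compound 2, with the step of a 1.8-fold lower number from compound 2 to compound 3 (0.26 log units; within the scatter) estimated as small and of uncertain sign. The estimate for compound 3 in this assay is 15000 nM, with a range from 5000 nM to 45000 nM.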

Compound 3, concentration for 50% growth inhibition: 23600 nM
Compound 3: the middle estimate sits 1.6-fold (0.20 log units) below what was measured; low and high end bracket the measured number.
By their numbers in this assay, from the lowest: compounds 1, 3 and 2 (each within the scatter of the next).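

Within this assay, the chain at this position now varies in length as well as in branching, and pentyl in place of isopropyl on a saturated chain carbon bound to an oxygen next to a carbonyl group gives a 1.1-fold lower number from compound 2 to compound 3 (0.06 log units; within the scatter). Ethyl in place of hydrogen on a saturated chain carbon, four bonds along the chain from an oxygen next to a carbonyl group, gives a 1.4-fold higher number from compound 1 to compound 3 (0.14 log units; within the scatter), so neither change separates these compounds, and compound 1, compound 2 and compound 3 cannot be ordered on these numbers. No other evidence on these compounds is available to account for this result.

As far as these compounds go, it remains open whether a longer chain, a benzyl group, or a chain carrying an amine or a carboxylic acid would move the number beyond the scatter. From the compounds shown here alone, it is also open whether these chains would behave alike in another cell line.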